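Swapping the aryl group on the piperazine of a weak transporter inhibitor

The compounds below may be only part of what the source reports. "The series", "measured", "known", "first", "only" and "open" are said of these compounds alone.

Compound 1 `O=C(CN1CCN(c2cccc(F)c2)CC1)Nc1nc2c(s1)CCCC2`: > 10000 nM
Compound 2 `CC1CCc2sc(NC(=O)CN3CCN(c4ccc(F)cc4)CC3)nc2C1`: 5100 nM
Compound 3 `O=C(CN1CCN(c2ccc(F)cc2)CC1)Nc1nc2c(s1)CCC2`: > 10000 nM

These three share a core in which a piperazine carries an aryl group and links through an amide to a fused thiazole. In an assay on isolated protein for inhibition of long-chain fatty acid transport protein 1 (Mus musculus), read by scintillation counting, with a stated time of 20 min (on this read-out higher numbers stand for weaker inhibition and lower numbers for stronger inhibition), compound 1 reaches only the limit, > 10000 nM. Compound 3 likewise gives only a limit, > 10000 nM. Compound 2 alone gives a number, 5100 nM. Compound 1 thus stands at the limit of > 10000 nM in this assay, at which 2 of the 3 values shown sit.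

Compound 4 `Cc1ccc(N2CCN(CC(=O)Nc3nc4c(s3)CCCC4)CC2)cc1` is not yet measured. It differs from compound 1 by 4-methylphenyl in place of 3-fluorophenyl on an amine nitrogen in a ring. Going by the values given here, no measured pair isolates this change, so the expectation rests on the weak values seen throughout. The step that the limit leaves unreadable from compound 1 to compound 4 is expected to stay within the scatter. Compound 4 is therefore estimated at 12000 nM, between 4000 nM and 40000 nM, quite possibly again only a limit.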

Compound 4, half-maximal inhibitory concentration: > 10000 nM
Compound 4: only a limit was reported (the forecaster's own chance of this, stated with the estimate: 60%); the middle value does not contradict the limit.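

Going by these compounds alone, compound 1 and compound 4 both give only a limit, so no step between them can be read: the limit of > 10000 nM in this assay, at which 3 of the 4 values shown sit.

The compounds shown leave open whether 4-methylphenyl in place of 3-fluorophenyl changes inhibition at all in this assay.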